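The source may hold more compounds than are shown below. What is called first, only, known or untested is meant among the compounds shown, and "the series" means these compounds.

Working notes on the series. The shared core carries a thiocarbamate-type sulfur link to a variable amine, and three members have been measured in a functional assay on A-375 cells (Homo sapiens) for antiproliferative activity, read by CCK-8 assay, with a stated time of 72 h, tested at 8 uM; on this read-out lower numbers stand for a weaker effect and higher numbers for a stronger effect at the one concentration tested. Compound 1 `Nc1ccccc1NC(=O)c1ccc(CSC(=S)N2CCN(C3CCCCC3)CC2)cc1` gives 89.9% in this assay. Among the compounds with values here, compound 3 `Nc1ccccc1NC(=O)c1ccc(CSC(=S)N2CCN(c3ccc(F)cc3)CC2)cc1` gives 76.3%, and the one clean step, a number 13.6 percentage points lower from compound 1 to compound 3 (beyond the scatter), shows 4-fluorophenyl in place of cyclohexyl on an amine nitrogen in a ring costing some activity. Compound 2 `CN(Cc1cccnc1)C(=S)SCc1ccc(C(=O)Nc2ccccc2N)cc1` gives 83.8%; its number sits among those of compound 1 and compound 3, but the gaps to each are within the scatter, so no order among the three can be claimed from it.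

Compound 4 `CN(C(=S)SCc1ccc(C(=O)Nc2ccccc2N)cc1)c1cccnc1` is the unmeasured member. Relative to compound 2, the change is pyridin-3-yl in place of (pyridin-3-yl)methyl on an amide-type nitrogen. Within the data shown here, no measured step touches this nitrogen or this kind of change, so the step from compound 1 to compound 3 does not bear on it directly. The expected step in this assay is a number 5.8 percentage points lower from compound 2 to compound 4 (within the scatter), likely within the scatter. Compound 4 is estimated at 78%, with a range from 60% to 92%.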

Compound 4, a percentage reported as inhibition, at one concentration (the size of the read-out at that concentration, not a potency): 87.7%
Compound 4: middle estimate off by 9.7 percentage points, on the low side; the measured number falls inside the stated range.
By their numbers in this assay, from the lowest: compounds 3, 2, 4 and 1 (each within the scatter of the next, the first and the last beyond it).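

Within the data shown here, the pyridin-3-yl in place of (pyridin-3-yl)methyl change gives the first measured step on this amide-type nitrogen: in this assay it is a number 3.9 percentage points higher from compound 2 to compound 4 (within the scatter). At this single concentration, therefore, compound 2 and compound 4 cannot be told apart, and the read-out tolerates either group at this position. Nothing at hand explains this outcome.

Both groups carry the same pyridine ring, so the compounds shown leave open whether the ring nitrogen matters here, which a plain phenyl or benzyl group would test. Also open, as far as these compounds go, are a longer chain, such as 2-(pyridin-3-yl)ethyl, on this nitrogen and an ethyl group in place of the methyl on the same nitrogen.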